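The compounds below may be only part of what the source reports. "The series", "measured", "known", "first", "only" and "open" are said of these compounds alone.

Series notes. The shared core, as in compound 1 `COc1ccc(-c2csc(N)c2C(=O)OCc2ccccc2)cc1OC`, carries benzyloxy on the carbonyl carbon; compound 2 `COc1ccc(-c2csc(N)c2C(=O)OCc2ccccc2F)cc1OC` differs by fluoro in place of hydrogen on an aromatic carbon, and compound 3 `COCCNC(=O)c1c(-c2ccc(OC)c(OC)c2)csc1N` by (2-methoxyethyl)amino in place of benzyloxy on a carbonyl carbon. In an assay on isolated protein for inhibition of protein kinase C zeta type (Homo sapiens), with stated times of 1 h and 2.5 min, tested at 30 uM (a higher number here means more inhibition at the concentration tested (going by the name of the read-out), a lower number less inhibition), compound 1 gives 100%, compound 2 gives 100% and compound 3 gives 55%. The step of no change at the digits printed from compound 1 to compound 2 (within the scatter) is flat, whereas a number 45 percentage points lower from compound 1 to compound 3 (beyond the scatter) and a number 45 percentage points lower from compound 2 to compound 3 (beyond the scatter) are both large drops, so compound 3 stands lowest of the three numbers in this assay, beyond the scatter from both others. Compound 4 `COc1ccc(-c2csc(N)c2C(=O)O)cc1OC` is the next step: hydroxy in place of (2-methoxyethyl)amino on a carbonyl carbon. Going by the values given here, the measured steps that bear on it are the changes at the same carbonyl carbon, a number 45 percentage points lower from compound 1 to compound 3 (beyond the scatter) and a number 45 percentage points lower from compound 2 to compound 3 (beyond the scatter); no measured step covers hydroxy entering there. Because a number 45 percentage points lower from compound 1 to compound 3 (beyond the scatter) and a number 45 percentage points lower from compound 2 to compound 3 (beyond the scatter) both show a large loss when benzyloxy at the carbonyl carbon is replaced, a further drop, a number 20 percentage points lower from compound 3 to compound 4 (beyond the scatter), is expected, though with wide uncertainty. Compound 4 is estimated at 35% in this assay, between 5% and 70%.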

Compound 4, a percentage reported as inhibition, at one concentration (the size of the read-out at that concentration, not a potency): 65%
Compound 4: the middle estimate sits 30 percentage points below what was measured, and the stated range covers the measured number.
By their numbers in this assay, from the lowest: compounds 3 and 4 (each within the scatter of the next); then compounds 1 and 2 (each within the scatter of the next).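

At the carbonyl carbon, in this assay the exchange of (2-methoxyethyl)amino for hydroxy gives a number 10 percentage points higher from compound 3 to compound 4 (within the scatter) and so does not separate the two groups, which means the further drop expected for the acid does not appear. Loss of the benzyl group from the ester oxygen gives a number 35 percentage points lower from compound 1 to compound 4 (beyond the scatter) and loss of 2-fluorobenzyl gives a number 35 percentage points lower from compound 2 to compound 4 (beyond the scatter), so both benzyl esters stand clear of the free carboxy compound, just as they stand clear of compound 3, while substantial inhibition remains without any benzyl group. No evidence at hand bears on the reason for these steps.

Still open, going by these compounds, is whether the benzyl group or the ester link carries the difference: benzylamino or a methyl ester on the same carbonyl carbon would separate the two. A longer chain on the amide nitrogen also remains to be placed against compound 3.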